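The source may hold more compounds than are shown below. What is called first, only, known or untested is meant among the compounds shown, and "the series" means these compounds.

Working notes on the pyrazole series, compound 4.

Three members have been measured in a functional assay on MDA-MB-231 cells (Homo sapiens) for inhibition, read by MTT assay, with a stated time of 48 h; on this read-out lower numbers stand for stronger inhibition and higher numbers for weaker inhibition. Compound 1 `COc1cc(-c2cc(/C=C3\CCc4ccccc4C3=O)[nH]n2)cc(OC)c1OC` gives 9500 nM. Compound 2 `COc1cc(-c2cc(/C=C/C(=O)c3ccc(Cl)c(Cl)c3)[nH]n2)cc(OC)c1OC` gives 2100 nM. Compound 3 `COc1ccc(-c2cc(/C=C/C(=O)c3ccc(N)cc3)[nH]n2)cc1OC` gives 2200 nM. Of the three numbers, compound 2 stands lowest; compound 3 sits within the usual scatter of it, so no order between the two is claimed, whereas compound 1 lies beyond the scatter and is the weakest of the three in this assay.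

The next step goes from compound 2 to compound 4 `COc1ccc(C(=O)/C=C/c2cc(-c3cc(OC)c(OC)c(OC)c3)n[nH]2)cc1F`. The change is a single replacement of the aryl group on the carbonyl carbon: 3-fluoro-4-methoxyphenyl in place of 3,4-dichlorophenyl on a carbonyl carbon. The carbonyl, the chain and the trimethoxyphenyl-bearing core are kept.

Within the data shown here, no measured pair in the set separates the effect of an aryl swap on the carbonyl carbon alone; the only comparable pair, compound 2 against compound 3, also differs in the methoxy pattern on the core, and their values fall within the scatter of each other. On that basis the step from compound 2 to compound 4 is expected to be small, a 1.2-fold higher number from compound 2 to compound 4 (0.08 log units; within the scatter), with no direction beyond the scatter claimed. Compound 4 is therefore estimated at 2500 nM, with a likely range from 1000 nM to 6500 nM.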

Compound 4, half-maximal inhibitory concentration: 2700 nM
Estimate against measurement, compound 4: 1.1-fold (0.03 log units) below, within the range that was stated.
By their numbers in this assay, from the lowest: compounds 2, 3 and 4 (each within the scatter of the next); then compound 1.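

Among these compounds, the step of a 1.3-fold higher number from compound 2 to compound 4 (0.11 log units; within the scatter) in this assay is the first comparison that changes one place only, with the carbonyl, the chain and the shared core held constant. It shows that, at this position on a carbonyl carbon, 3-fluoro-4-methoxyphenyl can stand in place of 3,4-dichlorophenyl without a change that can be separated from the scatter, even though the entering group has 1 hydrogen-bond acceptor and the leaving group has 0. No supporting measurement bears on why the two aryl groups give values this close.

Going by these compounds, a single step between two substituted phenyl groups sets no trend, so it remains open whether a group of another kind on the carbonyl carbon, such as a carboxylic acid or a morpholine, would stay within the same range. On these data alone, compound 3 differs from compound 2 and from compound 4 in more than one place, so it also remains open whether the aryl group of compound 3 would give a comparable value on the core of compound 2.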